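A Single Fluoro Substitution Seen in Two Compound Pairs

A few compounds are considered here, and "the series" means these few. Any claim that something is new, unique, unknown or untested is made for them only; others in the source may bear on it.

In a functional assay on the whole organism with Mus musculus as the target, in the rotarod test (a higher number here means that more compound is needed for the effect, a lower number that less compound is needed), compound 1 `CC(C)NC(=O)/C=C1\CCc2ccc(F)cc21` gives a value that is only a limit of the assay, > 100 mg/kg. Compound 2 `CC(C)NC(=O)/C=C1\CCc2c(F)cc(F)cc21` gives 76 mg/kg. The step of an at least 1.3-fold lower number from compound 1 to compound 2 (0.11 log units; that floor lies within the scatter) rests on (fluoro in place of hydrogen on an aromatic carbon). Compound 3 `NC(=O)/C=C1\CCc2ccccc21` gives 164 mg/kg, the highest of the two numbers recorded. The difference between the core of compound 1 and the core of compound 3 is not broken down here. Compound 4 `NC(=O)/C=C1\CCc2ccc(F)cc21` has not yet been measured; it differs from compound 3 by fluoro in place of hydrogen on an aromatic carbon, the same kind of change as that from compound 1 to compound 2, though the place differs: here it is meta to a fused ring and para to a fused ring, whereas there it was ortho to a fused ring and meta to a fluoro group. Because an at least 1.3-fold lower number from compound 1 to compound 2 (0.11 log units; that floor lies within the scatter) is only a floor lying within the scatter, a step of a 1.4-fold lower number from compound 3 to compound 4 (0.14 log units; within the scatter) is expected. Compound 4 is estimated at 120 mg/kg, probably between 60 mg/kg and 250 mg/kg.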

Compound 4, dose for half-maximal effect: 90 mg/kg
For compound 4 the middle estimate is 1.3-fold (0.12 log units) above the measured one, and the stated range covers the measured number.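

In this assay, fluoro in place of hydrogen on an aromatic carbon gives a 1.8-fold lower number from compound 3 to compound 4 (0.26 log units; within the scatter), and this can be set beside the same change on the other core: the same change on two cores in this assay, an at least 1.3-fold lower number (0.11 log units; that floor lies within the scatter) from compound 1 to compound 2 and a 1.8-fold lower number (0.26 log units; within the scatter) from compound 3 to compound 4; the limit leaves it open whether they differ. Both steps lie within the scatter and the places on the ring differ, which leaves it unshown whether the change acts alike on the two cores or has any effect on either. Hydrogen in place of isopropyl on an amide-type nitrogen gives an at least 1.1-fold lower number from compound 1 to compound 4 (0.04 log units; that floor lies within the scatter), which is only a floor, since compound 1 stands at a limit of the assay: the limit of > 100 mg/kg in this assay, at which 1 of the 4 values shown sits.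

The compounds shown leave open what a chloro or methoxy group would give on that aromatic carbon. They also leave open what an ethyl group or a longer chain would give on the amide-type nitrogen.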